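A few compounds are considered here, and "the series" means these few. Any claim that something is new, unique, unknown or untested is made for them only; others in the source may bear on it.

Going by the values given here, compound 3 `O=C1[C@@H](NS(=O)(=O)c2cc3ccc(Cl)nc3s2)CCN1Cc1cc2c[nH]ccc-2n1` stands highest of the three numbers measured so far. In an assay on isolated protein for inhibition of coagulation factor X (Oryctolagus cuniculus), tested at 1 uM (on this read-out higher numbers stand for more inhibition at the one concentration tested (going by the name of the read-out) and lower numbers for less inhibition), compound 3 gives 51%, while compound 2 `O=C1[C@@H](NS(=O)(=O)c2cc3cccnc3s2)CCN1Cc1cc2c[nH]ccc-2n1` gives 18% and compound 1 `O=C1[C@@H](NS(=O)(=O)c2ccc(-c3ccon3)s2)CCN1Cc1cc2c[nH]ccc-2n1` gives 17%. The step of a number 33 percentage points higher from compound 2 to compound 3 (beyond the scatter) and the step of a number 34 percentage points higher from compound 1 to compound 3 (beyond the scatter) are both large and beyond the scatter, whereas the step of a number 1 percentage points higher from compound 1 to compound 2 (within the scatter) lies within it.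

Compound 4 `O=C1[C@@H](NS(=O)(=O)c2cc3nc(Cl)ccc3s2)CCN1Cc1cc2c[nH]ccc-2n1` is the next compound and differs from compound 3 in the following way: a group of 10 heavy atoms (7 carbon, 1 nitrogen, 1 sulfur, 1 chlorine; one five-membered aromatic ring with 1 hetero atom, one six-membered aromatic ring with 1 hetero atom) in place of a group of 10 heavy atoms (7 carbon, 1 nitrogen, 1 sulfur, 1 chlorine; one five-membered aromatic ring with 1 hetero atom, one six-membered aromatic ring with 1 hetero atom), on a sulfonyl sulfur. Both compounds hold the same atoms, joined differently, and both keep the chloro that separated compound 2 from compound 3. Among the compounds with values here, none of the measured steps is a rearrangement of this kind, so no step bears on it directly; the only guidance is that compound 3 holds the high value 51% and compound 4 keeps every group of it. Compound 4 is therefore expected to show a modest downward step a number 13 percentage points lower from compound 3 to compound 4 (beyond the scatter) in this assay, with a wide margin. Compound 4 is estimated at 38%, in a range from 12% to 62%.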

Compound 4, a percentage reported as inhibition, at one concentration (the size of the read-out at that concentration, not a potency): 58%
Estimate against measurement, compound 4: 20 percentage points below, and the stated range covers the measured number.
By their numbers in this assay, from the lowest: compounds 1 and 2 (each within the scatter of the next); then compounds 3 and 4 (each within the scatter of the next).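

In this assay, joining the same atoms differently in the chloro-bearing group on the sulfonyl sulfur gives a number 7 percentage points higher from compound 3 to compound 4 (within the scatter), so this rearrangement does not move the read-out the way adding the chloro did. Compound 4 also keeps the large lead over the compounds without chloro, with a number 40 percentage points higher from compound 2 to compound 4 (beyond the scatter) and a number 41 percentage points higher from compound 1 to compound 4 (beyond the scatter), so the two chloro-bearing groups cannot be told apart here. Nothing among the data explains why these two groups read alike.

Going by these compounds, it remains open whether the group of compound 4 would read the same with hydrogen in place of the chloro. On these data alone, it is also open whether a methoxy, an amine or a carboxylic acid in place of the chloro would hold the level in this assay as well as the chloro does.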